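Minimum effective dose: hydrogen for fluoro on compound 3

The source may report more compounds than this note shows. Statements on the series, on what has been measured and on what is new or still open speak of the compounds shown alone.

Measured so far, all in a functional assay on the whole organism (strain NMRI) with Mus musculus as the target, with a stated time of 0.5 h; a higher number here means that more compound is needed for the effect, a lower number that less compound is needed:
Compound 1 `Cc1ccc(Cn2cc(CO/N=C/c3c(-c4ccc(C)cc4)nc4ccc(Br)cn34)nn2)cc1` gives 40 mg/kg.
Compound 2 `O/N=C/c1c(-c2ccc(F)cc2)nc2ccc(Br)cn12` gives 40 mg/kg.
Compound 3 `O=[N+]([O-])c1ccc(Cn2cc(CO/N=C/c3c(-c4ccc(F)cc4)nc4ccc(Br)cn34)nn2)cc1` gives 40 mg/kg.

Compound 3 stands level with compounds 1 and 2 at the digits read: its nearest neighbour on the numbers is compound 1, with no change at those digits, and its furthest is compound 2, also with no change at those digits. Both gaps sit within the scatter of this assay, so the three measured compounds cannot be ordered against one another on these data.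

Compound 4 `O=[N+]([O-])c1ccc(Cn2cc(CO/N=C/c3c(-c4ccccc4)nc4ccc(Br)cn34)nn2)cc1` has not yet been measured in this assay. It differs from compound 3 in one place only: hydrogen in place of fluoro on an aromatic carbon. Cut one bond further out, the change reads 4-fluorophenyl to phenyl.

Within the data shown here, no step between measured compounds that differ in one place is available, so the size of this step has no direct precedent here. Given that compounds 1, 2 and 3 all sit at the same dose in this assay, the step from compound 3 to compound 4 is expected to be none beyond the scatter, in either direction.

For compound 4 the minimum effective dose in this assay is estimated at 40 mg/kg, with a range from 20 mg/kg to 80 mg/kg, which means an expected step of no change at the digits printed from compound 3 to compound 4 (within the scatter).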

Compound 4, minimum effective dose: 20 mg/kg
Beside the measured number, compound 4's estimate is 2.0-fold (0.30 log units) above it; measured number inside the range.
By their numbers in this assay, from the lowest: compounds 4, 1, 2 and 3 (each within the scatter of the next).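

In this assay the series now has its first step between compounds that differ in one place: a 2.0-fold lower number from compound 3 to compound 4 (0.30 log units; within the scatter). On this aromatic carbon, para to a large group, the exchange of fluoro for hydrogen leaves the minimum effective dose within the scatter, so this pair gives no sign that the fluoro is needed for the effect at the dose level read here. No measurement shown bears on the reason for this outcome.

The pair covers only the smallest exchange at this position, and a single step cannot show how far the position tolerates other groups; an amine, a carboxylic acid or a methoxy group on the same carbon would test that. Compound 1 does carry a methyl group on this ring, but it also differs from compound 3 on the benzyl group, so it does not give a clean reading of the position, and the other end of the molecule remains unresolved in the same way.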